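Methylating the Ring Amine of Compound 1

The compounds below may be only part of what the source reports. "The series", "measured", "known", "first", "only" and "open" are said of these compounds alone.

Compound 1, `COCC[C@H]1C[C@@H]1c1cncc(N2CCCNCC2)c1`, in an assay on a protein complex for displacement of a labelled ligand from Neuronal acetylcholine receptor; alpha4/beta4 (Rattus norvegicus), read by scintillation counting; on this read-out lower numbers stand for stronger inhibition and higher numbers for weaker inhibition: 151 nM
Compound 2, `COCC[C@@H]1C[C@H]1c1cncc(N2CCCNCC2)c1`, in this assay: 168 nM

Compound 1 stands lowest of the two numbers. Compound 2 is its mirror image, and the step of a 1.1-fold higher number from compound 1 to compound 2 (0.05 log units; within the scatter) is small because of the fact that compounds 1 and 2 differ only in the configuration as drawn.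

Compound 3, `COCC[C@H]1C[C@@H]1c1cncc(N2CCCN(C)CC2)c1`, carries methyl in place of hydrogen on an amine nitrogen in a ring. Going by the values given here, no measured step tests this change; the mirror-image step says nothing about a methyl on the ring nitrogen. The step is therefore expected to be a 1.7-fold higher number from compound 1 to compound 3 (0.22 log units; within the scatter), within or barely beyond the scatter. In this assay compound 3 is expected to give 250 nM, between 70 nM and 900 nM.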

Compound 3, inhibition constant: 4810 nM
Compound 3: middle estimate off by 19-fold (1.28 log units), on the low side; the whole stated range lies below it.
By their numbers in this assay, from the lowest: compounds 1 and 2 (each within the scatter of the next); then compound 3.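

In this assay methyl in place of hydrogen on this amine nitrogen in a ring gives a 32-fold higher number from compound 1 to compound 3 (1.50 log units; beyond the scatter) and so shows that this position responds strongly to a single added carbon. The mirror-image pair, compounds 1 and 2, gave no step beyond the scatter, so this one methyl matters far more here than the configuration as drawn. Nothing available explains why the methyl has so large an effect.

From the compounds shown here alone, whether a longer chain such as ethyl on this nitrogen would give a higher number still remains open. So does whether the same methyl would have a similar effect on compound 2.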